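Tolerance of HEL Cells for Compounds 1 to 4

This account rests on a few compounds, and the source may have more. Where it says the series, first, only, none or still open, it means among the compounds named here.

Compound 1 `CCC1(Cc2ccccc2)OS(=O)(=O)C=C1OCc1ccccc1`: a limit, >= 50000 nM in an ADME assay on HEL cells (Homo sapiens) for cytotoxicity, with a stated time of 3 days; a higher number here means that more compound is tolerated, a lower number that less compound is tolerated.
Compound 2 `CCC1(Cc2ccccc2)OS(=O)(=O)C=C1OCc1ccc(Cl)cc1`: a limit, >= 50000 nM.
Compound 3 `CCC1(Cc2ccccc2)OS(=O)(=O)C=C1OCC#N`: a limit, > 400000 nM.

Every value here is a limit of the assay, not a number. Compound 3 sits at the limit of > 400000 nM in this assay, at which 1 of the 3 values shown sits. Compounds 1 and 2 sit at the limit of >= 50000 nM in this assay, at which 2 of the 3 values shown sit. Hence the steps a step that the two limits leave unreadable from compound 1 to compound 3, a step that the two limits leave unreadable from compound 2 to compound 3 and a step that the two limits leave unreadable from compound 1 to compound 2 cannot be sized. Compound 4 `CCC1(Cc2ccccc2)OS(=O)(=O)C=C1OC` differs from compound 3 by hydrogen in place of cyano on a saturated chain carbon bound to an oxygen on an unsaturated carbon. Among the measured compounds shown here, the steps that bear on this change are the two leading into compound 3, both unreadable, so no direction beyond the scatter can be read from them. For the measured compounds named here, as no compound yet showed a readable cytotoxic concentration, compound 4 is expected to give 300000 nM in this assay, between 50000 nM and 400000 nM. The expected step is an at least 1.3-fold lower number from compound 3 to compound 4 (0.12 log units; that floor lies within the scatter).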

Compound 4, minimum cytotoxic concentration: > 400000 nM
Compound 4: a limit, no number (the forecaster's own chance of this, stated with the estimate: 85%); at least 1.3-fold (0.12 log units) between middle value and limit.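

Compound 4 gives only a limit of the assay, as do compounds 1, 2 and 3, so none of its steps from those compounds can be read. The compounds shown leave open at what concentration any of them stops being tolerated.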